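Exchanging the phenoxy group for a chloroanilino group

This account rests on a few compounds, and the source may have more. Where it says the series, first, only, none or still open, it means among the compounds named here.

Within the data shown here, the series shares one core, and the three compounds measured so far differ only in the group on one aromatic carbon. Compound 1 `Cc1cc(C2CCC2)c(S(C)(=O)=O)cc1C(=O)N=C(N)N` carries a cyclobutyl group there and gives 8.2 nM in a functional assay for inhibition of sodium/hydrogen exchanger (Oryctolagus cuniculus); a higher number here means a weaker inhibitor, a lower number a stronger inhibitor. Compound 2 `Cc1cc(-c2cc(Cl)cc(Cl)c2)c(S(C)(=O)=O)cc1C(=O)N=C(N)N` carries a 3,5-dichlorophenyl group and gives 130 nM. Compound 3 `Cc1cc(Oc2ccccc2)c(S(C)(=O)=O)cc1C(=O)N=C(N)N` carries a phenoxy group and gives 10 nM; it stands second highest of the three numbers, with compound 1 nearest and compound 2 furthest. The step of a 1.2-fold higher number from compound 1 to compound 3 (0.09 log units; within the scatter) lies within the scatter, whereas a 13-fold lower number from compound 2 to compound 3 (1.11 log units; beyond the scatter) is large.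

Compound 4 `Cc1cc(Nc2cccc(Cl)c2)c(S(C)(=O)=O)cc1C(=O)N=C(N)N` is the next compound and has not yet been measured. It differs from compound 3 in one place:

(3-chlorophenyl)amino in place of phenoxy on an aromatic carbon

Among the measured compounds shown here, two measured steps bear on this change. The step of a 1.2-fold higher number from compound 1 to compound 3 (0.09 log units; within the scatter) shows that the phenoxy group is interchangeable with cyclobutyl, and the step of a 13-fold lower number from compound 2 to compound 3 (1.11 log units; beyond the scatter) shows that a directly attached dichlorophenyl ring gives a much higher number than phenoxy. Compound 4 keeps a single linking atom between the two rings, as compound 3 does, so a step of a 1.5-fold higher number from compound 3 to compound 4 (0.18 log units; within the scatter) is expected, within or close to the scatter. Compound 4 is therefore estimated at 15 nM, within a range from 5 nM to 50 nM.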

Compound 4, half-maximal inhibitory concentration: 33 nM
Compound 4: the middle estimate sits 2.2-fold (0.34 log units) below what was measured; low and high end bracket the measured number.
By their numbers in this assay, from the lowest: compounds 1 and 3 (each within the scatter of the next); then compound 4; then compound 2.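

The result shows that this position, ortho to a methylsulfonyl group, does not treat every ring-bearing group with a linking atom alike: in this assay the exchange for (3-chlorophenyl)amino gives a 3.3-fold higher number from compound 3 to compound 4 (0.52 log units; beyond the scatter), a modest rise beyond the scatter. Compound 4 also takes an intermediate place, with a 3.9-fold lower number from compound 2 to compound 4 (0.60 log units; beyond the scatter) on one side and a 4.0-fold higher number from compound 1 to compound 4 (0.60 log units; beyond the scatter) on the other, so the linked chlorophenyl group gives a lower number than the directly attached 3,5-dichlorophenyl group but does not match cyclobutyl. Nothing shown here gives a measured account of these steps.

The change replaces the linking oxygen with an amine nitrogen and adds a chlorine to the ring, and the compounds shown do not separate these two parts. An unsubstituted phenylamino group or a 3-chlorophenoxy group at this position would show which part carries the rise, while a phenylthio group would extend the comparison to a sulfur link.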